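The compounds below may be only part of what the source reports. "The series", "measured", "known", "first", "only" and "open" are said of these compounds alone.

Measured in an ADME assay on L929 cells (Mus musculus) for cytotoxicity, read by resazurin assay, with a stated time of 72 h; a lower number here means a stronger inhibitor, a higher number a weaker inhibitor:
- compound 1 `CCc1ccc(C(=O)/C=C/c2ccc3c(c2)B(O)OC3)cc1`: > 10 ug/mL (a limit)
- compound 2 `O=C(/C=C/c1ccc2c(c1)B(O)OC2)c1ccccc1`: > 10 ug/mL (a limit)

Compound 2 stands at > 10 ug/mL, which is a limit of the assay and not a number. Going by the values given here, the series so far consists of the limit of > 10 ug/mL in this assay, at which 2 of the 2 values shown sit.

Compound 3 `O=C(/C=C/c1ccc2c(c1)B(O)OC2)c1ccc([N+](=O)[O-])cc1` differs from compound 2 by nitro in place of hydrogen on an aromatic carbon. The nitro group sits on an aromatic carbon, para to a large group.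

Among the compounds with values here, the only measured step is a step that the two limits leave unreadable from compound 1 to compound 2. With no readable size, it sets neither a size nor a direction for this change, so any expectation in this assay is weakly founded. No clear shift is expected, and another limit is the likeliest report. The expected step is a step that the limit leaves unreadable from compound 2 to compound 3. For compound 3 the estimated value is 12 ug/mL, with an expected range of 3 ug/mL to 40 ug/mL.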

Compound 3, half-maximal inhibitory concentration: > 10 ug/mL
Compound 3: only a limit was reported; the forecaster's own chance of this, stated with the estimate: 65%; the middle value is on the limit's open side.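

In this assay compound 3 gives > 10 ug/mL, which is a limit and not a number. No new step can be read among compound 1, compound 2 and compound 3. The compounds shown leave open whether ethyl or nitro in place of hydrogen shifts the half-maximal inhibitory concentration at all, with the whole series resting on one reading: the limit of > 10 ug/mL in this assay, at which 3 of the 3 values shown sit.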